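Swapping an anilide for an ester on a shared phenol core

This account rests on a few compounds, and the source may have more. Where it says the series, first, only, none or still open, it means among the compounds named here.

Measured compounds:
- compound 1 `CCC(C)OC(=O)c1cc(CN2CCCC2)c(O)c(CN2CCCC2)c1`: 6.7 ug/mL
- compound 2 `CC(C)OC(=O)CCc1cc(CN2CCCC2)c(O)c(CN2CCCC2)c1`: 4 ug/mL
- compound 3 `O=C(Nc1ccccc1)c1cc(CN2CCCC2)c(O)c(CN2CCCC2)c1`: 11 ug/mL

All three compounds share one core and differ only in the group attached to it. In a functional assay for inhibition, with Cavia porcellus as the target (on this read-out higher numbers stand for an effect only at larger amounts of compound and lower numbers for an effect already at smaller amounts), compound 3 gives the highest number of the three; the step of a 1.6-fold higher number from compound 1 to compound 3 (0.22 log units; within the scatter) stays within the scatter, while the step of a 2.8-fold higher number from compound 2 to compound 3 (0.44 log units; beyond the scatter) lies beyond it. Compound 4 `CC(C)COC(=O)CCc1cc(CN2CCCC2)c(O)c(CN2CCCC2)c1` is the next compound, not yet measured. Its change from compound 3 is 2-(isobutoxycarbonyl)ethyl in place of phenylcarbamoyl on an aromatic carbon.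

Among the measured compounds shown here, two measured steps bear on this change. For the measured compounds named here, the step of a 2.8-fold higher number from compound 2 to compound 3 (0.44 log units; beyond the scatter) runs in the opposite direction to the one now taken, since compound 2 carries 2-(isopropoxycarbonyl)ethyl, an ester chain of the same length as the one entering in compound 4. The step of a 1.7-fold lower number from compound 1 to compound 2 (0.22 log units; within the scatter) shows that changing the ester part alone moved the number only within the scatter. Compound 4 is therefore expected to come in modestly lower than compound 3 in this assay, by about the reverse of the earlier step, giving an estimated 2.4-fold lower number from compound 3 to compound 4 (0.39 log units; beyond the scatter). The expected value for compound 4 is 4.5 ug/mL, with a likely range from 2 ug/mL to 10 ug/mL.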

Compound 4, concentration for half-maximal effect: 14 ug/mL
For compound 4 the middle estimate is 3.1-fold (0.49 log units) below the measured one; the whole stated range lies below it.
By their numbers in this assay, from the lowest: compounds 2, 1, 3 and 4 (each within the scatter of the next, the first and the last beyond it).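

In this assay, the step of a 1.3-fold higher number from compound 3 to compound 4 (0.10 log units; within the scatter) shows that 2-(isobutoxycarbonyl)ethyl and phenylcarbamoyl cannot be told apart on this aromatic carbon, para to the hydroxy group, even though the entering group has no ring and no hydrogen-bond donor. The ester chain alone therefore does not secure the low number seen for compound 2: with only isobutyl in place of isopropyl on the ester oxygen, the step of a 3.5-fold higher number from compound 2 to compound 4 (0.54 log units; beyond the scatter) lies beyond the scatter, and so does the step of a 2.1-fold higher number from compound 1 to compound 4 (0.32 log units; beyond the scatter). At this position, then, the group at the far end of the ester chain can matter as much as the choice between the ester chain and the anilide, at least among these four compounds.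

Nothing available here explains why isobutyl and isopropyl part in this way. On these data alone, how a methyl ester or a free carboxylic acid at the end of the same chain, or a longer chain between the ring and the ester, would read in this assay remains open.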